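Difluoromethoxy in place of fluoro: expected clearance

This account rests on a few compounds, and the source may have more. Where it says the series, first, only, none or still open, it means among the compounds named here.

Measured so far:
compound 1, `Fc1ccccc1C1Cc2nccn2C1`: "not determined" (no result reported)
compound 2, `c1ccc(C2Cc3nccn3C2)cc1`: 15 mL.min-1.g-1; < 7 mL.min-1.g-1 (2 entries)

In an in vitro ADME assay on microsomes from liver (Homo sapiens) for metabolic stability (on this read-out higher numbers stand for fast clearance and lower numbers for slow clearance), compound 1 has no single number; a further entry also gives none. Compound 2 shows two entries, one a numeric result, the other a limit of the assay rather than a number, as the evidence the several entries of compound 2 in this assay, 15 mL.min-1.g-1; < 7 mL.min-1.g-1 (2 entries) shows. Compound 3, `FC(F)Oc1ccccc1C1Cc2nccn2C1`, carries difluoromethoxy in place of fluoro on an aromatic carbon. Within the data shown here, with no measured step to lean on, the change from compound 1 to compound 3 is expected to stay within the usual scatter of this assay, in no clear direction. Compound 3 is estimated at 20 mL.min-1.g-1, between 7 mL.min-1.g-1 and 60 mL.min-1.g-1.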

Compound 3, intrinsic clearance in microsomes: 22 mL.min-1.g-1
Compound 3: the middle estimate sits 1.1-fold (0.04 log units) below what was measured, and the stated range covers the measured number.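

Compound 1 has no single number in this assay, so no step from compound 1 to compound 3 can be read, and nothing else shown bears on the result of compound 3. From the compounds shown here alone, whether difluoromethoxy in place of fluoro shifts clearance stays open.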